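The source may hold more compounds than are shown below. What is called first, only, known or untested is meant among the compounds shown, and "the series" means these compounds.

Measured compounds:
compound 1, `CCOC(=O)[C@@]1(C(=O)Nc2ccccc2)C[C@@H]1c1cc(OC)c(OC)c(OC)c1`: > 100000 nM
compound 2, `COc1cc([C@H]2C[C@@]2(CO)C(=O)Nc2ccccc2)cc(OC)c1OC`: > 100000 nM
compound 3, `COc1cc([C@H]2C[C@]2(CO)C(=O)Nc2ccccc2Cl)cc(OC)c1OC`: 36700 nM

Three compounds of this set have been run in a functional assay on A549 cells (Homo sapiens) for cytotoxicity, read by MTT assay, with a stated time of 48 h; a higher number here means a weaker inhibitor, a lower number a stronger inhibitor. For compound 1 the result is a limit of the assay rather than a number, > 100000 nM. For compound 2 the result is likewise a limit, > 100000 nM. Compound 3 alone gives a number, 36700 nM in this assay, while its two companions sit at the limit of > 100000 nM in this assay, at which 2 of the 3 values shown sit.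

Compound 1 and compound 2 share a core and differ in one place: ethoxycarbonyl in place of hydroxymethyl on a saturated ring carbon. The step this change makes, a step that the two limits leave unreadable from compound 2 to compound 1, is bounded by limits at both ends and so gives no size to carry over. Compound 3 and compound 2 differ by more than one change; the difference between their cores is not broken down here.

Compound 4, `CCOC(=O)[C@]1(C(=O)Nc2ccccc2Cl)C[C@@H]1c1cc(OC)c(OC)c(OC)c1`, has not yet been measured. It relates to compound 3 as compound 1 relates to compound 2: ethoxycarbonyl in place of hydroxymethyl on a saturated ring carbon. The two changes are the same. Since the earlier step is unreadable, the expectation rests on compound 3 and its value 36700 nM, with the change itself treated as roughly neutral. The step that this estimate means, a 1.5-fold higher number from compound 3 to compound 4 (0.18 log units; within the scatter), is expected to be modest. Compound 4 is therefore expected to land near 55000 nM in this assay. The range for compound 4 is expected to run from 12000 nM to 150000 nM, and a limit rather than a number would not be surprising.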

Compound 4, half-maximal inhibitory concentration: 50900 nM
Estimate against measurement, compound 4: 1.1-fold (0.03 log units) above, and the stated range covers the measured number.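

In this assay, ethoxycarbonyl in place of hydroxymethyl on a saturated ring carbon gives a 1.4-fold higher number from compound 3 to compound 4 (0.14 log units; within the scatter), so on the core of compound 3 this change cannot be told apart from no change at all. The same change on the core of compound 2 offers no size to set beside it, as compound 1 and compound 2 each stand at a limit of the assay rather than at a number: the limit of > 100000 nM in this assay, at which 2 of the 4 values shown sit. The series therefore holds one readable instance of the change, which shows that it can be made on the core of compound 3 without a step beyond the scatter, but it does not show that the change behaves alike on both cores, and a single pair cannot establish a rule for carrying it over.

Going by these compounds, what remains open is whether any other group on that ring carbon, such as a carboxylic acid, an amine or a longer chain in place of the ethoxycarbonyl, would move the read-out in this assay by more than the scatter. On these data alone, it is also open whether the change would give a readable step on a further core whose two members both return numbers.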